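Adding an Ethyl Group to a Piperidinyl Analogue

The source may report more compounds than this note shows. Statements on the series, on what has been measured and on what is new or still open speak of the compounds shown alone.

Compound 1, `CCc1cc(Cl)c(S(C)(=O)=O)cc1C(=O)N=C(N)N`, gives 63 nM in a functional assay for inhibition of sodium/hydrogen exchanger (Oryctolagus cuniculus); a lower number here means a stronger inhibitor, a higher number a weaker inhibitor.
Compound 2, `CCc1cc(Br)c(S(C)(=O)=O)cc1C(=O)N=C(N)N`, gives 41 nM in this assay.
Compound 3, `CS(=O)(=O)c1cc(C(=O)N=C(N)N)ccc1N1CCCCC1`, gives 130 nM in this assay.

Compound 3 has the highest number of the three measured compounds, so it is the weakest inhibitor among them. Compound 4, `CCc1cc(N2CCCCC2)c(S(C)(=O)=O)cc1C(=O)N=C(N)N`, differs from compound 3 by one change: ethyl in place of hydrogen on an aromatic carbon.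

Only one measured step links two of these compounds, a 1.5-fold lower number from compound 1 to compound 2 (0.19 log units; within the scatter), and it concerns a halogen swap, not the addition of an ethyl group. Among the compounds with values here, no measured pair shows what adding an ethyl group alone does. Compound 1 and compound 2 both carry an ethyl group and have lower numbers than compound 3, but they also differ from compound 3 in the group next to the methylsulfonyl group, so that gap cannot be attributed to the ethyl group by itself.

On this thin basis, a moderate improvement is expected, roughly a 1.9-fold lower number from compound 3 to compound 4 (0.27 log units; within the scatter). Compound 4 is therefore estimated at 70 nM, within a range of 25 nM to 200 nM.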

Compound 4, half-maximal inhibitory concentration: 25 nM
The estimate for compound 4 lay 2.8-fold (0.45 log units) above the measured number; measured number inside the range.
By their numbers in this assay, from the lowest: compounds 4, 2 and 1 (each within the scatter of the next, the first and the last beyond it); then compound 3.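

Ethyl in place of hydrogen, on the aromatic carbon para to the methylsulfonyl group, is the first change at this position that can be read on its own: in this assay it gives a 5.2-fold lower number from compound 3 to compound 4 (0.72 log units; beyond the scatter), so this carbon does influence the read-out, at least with the piperidin-1-yl group present. With ethyl in place, piperidin-1-yl in place of bromo gives a 1.6-fold lower number from compound 2 to compound 4 (0.21 log units; within the scatter), while piperidin-1-yl in place of chloro gives a 2.5-fold lower number from compound 1 to compound 4 (0.40 log units; beyond the scatter), so the larger group is tolerated alongside ethyl. No measurement here explains the effect of the ethyl group.

The compounds shown leave open whether a methyl group, a longer chain such as propyl, or an amine on this carbon would give a step of similar size. They also leave open whether ethyl would have a similar effect with chloro or bromo in place of piperidin-1-yl.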